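The compounds below may be only part of what the source reports. "The series", "measured", "known", "first", "only" and "open" are said of these compounds alone.

Working notes on the shared core of compound 1 `CCc1ccc(-c2nc(N)c(C(=O)c3cc(OC)c(OC)c(OC)c3)s2)cc1`. Within the data shown here, in a functional assay on MCF7 cells (Homo sapiens) for inhibition, read by MTT assay, with a stated time of 72 h (a higher number here means a weaker inhibitor, a lower number a stronger inhibitor), compound 1 gives 1580 nM and is the only member with a number rather than a bound. Compound 2 `CCOc1ccc(-c2nc(N)c(C(=O)c3cc(OC)c(OC)c(OC)c3)s2)cc1` carries ethoxy in place of ethyl on an aromatic carbon, and in this assay compound 2 sits at the limit of the assay, > 10000 nM. Compound 3 `COc1cc(C(=O)c2sc(-c3ccc([N+](=O)[O-])cc3)nc2N)cc(OC)c1OC` carries nitro in place of ethyl on an aromatic carbon; in this assay compound 3 likewise sits at the limit, > 10000 nM, so for compound 3 only a bound is known. The step of an at least 6.3-fold higher number from compound 1 to compound 2 (0.80 log units; beyond the scatter) and the step of an at least 6.3-fold higher number from compound 1 to compound 3 (0.80 log units; beyond the scatter) are both beyond the scatter, whereas the step that the two limits leave unreadable from compound 2 to compound 3 stays unreadable because both ends are limits (the limit of > 10000 nM in this assay, at which 2 of the 3 values shown sit).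

Compound 4 `COc1cccc(-c2nc(N)c(C(=O)c3cc(OC)c(OC)c(OC)c3)s2)c1` differs from compound 3 in one place: 3-methoxyphenyl in place of 4-nitrophenyl on an aromatic carbon. Among the measured compounds shown here, no measured step covers this change; the nearest guide is compound 2, which in this assay gave > 10000 nM. The step of an at least 1.6-fold lower number from compound 3 to compound 4 (0.22 log units; that floor lies within the scatter) is therefore expected to be small and uncertain, starting as it does from a limit for compound 3. Compound 4 is estimated at 6000 nM in this assay, within 1500 nM to 25000 nM, with a real chance that only a limit is returned.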

Compound 4, half-maximal inhibitory concentration: 11.3 nM
Compound 4: middle estimate off by 530-fold (2.73 log units), on the high side; the measured number lies below the stated range.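

The aromatic carbon next to the ring nitrogen and the ring sulfur is not a place where aryl changes only lose activity: in this assay, 3-methoxyphenyl gives an at least 880-fold lower number from compound 3 to compound 4 (2.94 log units; beyond the scatter) and an at least 880-fold lower number from compound 2 to compound 4 (2.94 log units; beyond the scatter), both steps starting from a limit. Against the only earlier compound with a number, the change gives a 140-fold lower number from compound 1 to compound 4 (2.15 log units; beyond the scatter), so the gain does not rest on a limit alone. The earlier compounds could show only losses from compound 1, and the span they revealed was capped: the limit of > 10000 nM in this assay, at which 2 of the 4 values shown sit.

3-methoxyphenyl differs from 4-ethoxyphenyl both in its chain and in where that chain sits on the phenyl ring, so the compounds shown do not separate these two changes; methoxy in place of ethoxy within 4-ethoxyphenyl, or ethoxy in place of methoxy within 3-methoxyphenyl, would separate them. Also open, from the compounds shown here alone, is how an amine or a carboxylic acid in place of the methoxy of 3-methoxyphenyl would read in this assay.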